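A few compounds are considered here, and "the series" means these few. Any claim that something is new, unique, unknown or untested is made for them only; others in the source may bear on it.

Compound 1 `Cc1ccccc1-c1nc(CN2CCC(C(=O)NCCCN3CCC(C)(C)CC3)CC2)c(C)o1` gives > 69 ug/mL in a physicochemical assay for solubility, in phosphate buffer, measured as kinetic solubility, at pH 7.4; on this read-out lower numbers stand for lower solubility and higher numbers for higher solubility; this is a limit of the assay, not a number.
Compound 2 `Cc1oc(-c2c(Cl)cccc2Br)nc1CN1CCC(C(=O)NCCCN2C[C@H](C)C[C@H](C)C2)CC1` gives > 83 ug/mL in this assay; this also is a limit of the assay.
Compound 3 `Cc1cccc(Cl)c1-c1nc(CN2CCC(C(=O)NCCCN3CCCC(C)C3)CC2)c(C)o1` gives 52.6 ug/mL in this assay.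

These three compounds share one core but differ from each other in more than one place, so no single structural step can be read off between any two of them. Compound 2 stands at the limit of > 83 ug/mL in this assay, at which 1 of the 3 values shown sits, which means its solubility is known only as a floor and not as a measured number. Of the three values shown, two are such limits and only compound 3 has a number.

Compound 4 `Cc1cc(C)cc(-c2nc(CN3CCC(C(=O)NCCCN4C[C@H](C)C[C@H](C)C4)CC3)c(C)o2)c1` arises from compound 2 by one change: 3,5-dimethylphenyl in place of 2-bromo-6-chlorophenyl on an aromatic carbon. The group that leaves and the group that enters are matched in size, with the same count of heavy atoms and no hydrogen-bond donors or acceptors on either side. For the measured compounds named here, no measured pair in this set isolates this change, so there is nothing to calibrate it against.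

The step of an at least 1.0-fold lower number from compound 2 to compound 4 (0.01 log units; that floor lies within the scatter) is expected to be small, no larger than the usual scatter in either direction. Compound 4 is therefore expected to sit near the limit, at about 80 ug/mL, with a plausible range from 40 ug/mL to 160 ug/mL.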

Compound 4, solubility: > 71 ug/mL
Compound 4 was reported as a limit (the forecaster's own chance of this, stated with the estimate: 50%); the middle value does not contradict the limit.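

For the compounds shown here, compound 2 and compound 4 are both reported in this assay only as limits of the assay, so no step between them can be read. The compounds shown leave open whether 3,5-dimethylphenyl in place of 2-bromo-6-chlorophenyl makes any difference on this read-out, and how far the true values of compound 2 and compound 4 lie past their limits.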